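The source may hold more compounds than are shown below. What is called first, only, known or untested is meant among the compounds shown, and "the series" means these compounds.

In a functional assay on SK-OV-3 cells (Homo sapiens) for cytotoxicity; on this read-out higher numbers stand for an effect only at larger amounts of compound and lower numbers for an effect already at smaller amounts:
Compound 1 `CC1=C(O)[C@@H](C/C(C)=C\CC[C@H](C)/C=C/C=C(\C)CCCc2ccoc2)OC1=O` gives 9.6 ug/mL
Compound 2 `CCC(C)CN1CC=C(CCC/C(C)=C/C=C/[C@@H](C)CC/C=C(/C)C[C@@H]2OC(=O)C(C)=C2O)C1=O` gives 6.9 ug/mL

Among the measured compounds shown here, on these two numbers, compound 2 has compound 1 as its only neighbour, and the two values lie within the scatter of each other, so nothing separates them. Compound 3 `CCC(C)CN1CC=C(CCC/C(C)=C/C=C/[C@@H](C)CC/C=C(/C)C[C@H]2OC(=O)C(C)=C2O)C1=O` has the same atoms and bonds as compound 2; the whole difference is this: the two compounds have the same atoms and bonds; at least one stereo element is drawn with a configuration in one of them and without one in the other: 1 of 6 stereo elements differ; a stereocentre at a saturated ring carbon is drawn S in compound 2 and R in compound 3. For the measured compounds named here, no pair of measured compounds shows what such a change does here. A step no larger than the scatter, with no clear direction, is expected, a 1.2-fold higher number from compound 2 to compound 3 (0.06 log units; within the scatter). Compound 3 is estimated at 8 ug/mL in this assay, within a range from 3 ug/mL to 25 ug/mL.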

Compound 3, concentration for half-maximal effect: 26.8 ug/mL
Beside the measured number, compound 3's estimate is 3.4-fold (0.53 log units) below it; measured number above the stated range.
By their numbers in this assay, from the lowest: compounds 2 and 1 (each within the scatter of the next); then compound 3.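

In this assay, the configuration at this saturated ring carbon matters even with atoms and bonds unchanged: a 3.9-fold higher number from compound 2 to compound 3 (0.59 log units; beyond the scatter). The exchange of the group of 5 heavy atoms for the group of 11 heavy atoms now also leaves a readable step, a 2.8-fold higher number from compound 1 to compound 3 (0.45 log units; beyond the scatter), although compound 1 and compound 2 lay within the scatter of each other. The comparison of the two stereo forms rests on one structural fact: the fact that one of compounds 2 and 3 is drawn with a defined configuration and the other without, at the place where they differ

As far as these compounds go, whether S still gives the lower number with a carboxylic acid or a longer chain in place of the group of 11 heavy atoms remains open.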